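Adding Chlorine to the Hydroxyphenyl Ring of Compound 1

The source may report more compounds than this note shows. Statements on the series, on what has been measured and on what is new or still open speak of the compounds shown alone.

Within the data shown here, compound 1 `Oc1ccc(CNc2cc(C(F)(F)F)cc3[nH]ncc23)cc1` has been tested in an assay for inhibition of Tryptophan 2,3-dioxygenase (Homo sapiens), with stated times of 10 min and 60 min (on this read-out higher numbers stand for weaker inhibition and lower numbers for stronger inhibition), where compound 1 gives 2550 nM, the lower of the two numbers known. Among the measured compounds shown here, the only other measured compound, compound 2 `FC(F)(F)c1cc(NC[C@H]2CCCN2)c2cn[nH]c2c1`, gives 6090 nM; that step was a 2.4-fold higher number from compound 1 to compound 2 (0.38 log units; beyond the scatter), but it exchanges the whole hydroxyphenyl group and says nothing about adding a halogen. Compound 3 `Oc1ccc(CNc2cc(C(F)(F)F)cc3[nH]ncc23)c(Cl)c1` differs from compound 1 by chloro in place of hydrogen on an aromatic carbon. For the measured compounds named here, no measured step bears on this change, so no step beyond the scatter is expected. Compound 3 is estimated at 2200 nM, between 800 nM and 6000 nM, an expected step of a 1.2-fold lower number from compound 1 to compound 3 (0.06 log units; within the scatter).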

Compound 3, half-maximal inhibitory concentration: 2680 nM
For compound 3 the middle estimate is 1.2-fold (0.09 log units) below the measured one; the measured number falls inside the stated range.
By their numbers in this assay, from the lowest: compounds 1 and 3 (each within the scatter of the next); then compound 2.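

In this assay chloro in place of hydrogen on this aromatic carbon, ortho to a large group and meta to a hydroxy group, gives a 1.1-fold higher number from compound 1 to compound 3 (0.02 log units; within the scatter) and so a read-out that cannot be told apart from that of compound 1. The exchange of the whole hydroxyphenyl group could not show that this carbon accepts a chlorine atom in this way. No supporting data explain this result. Going by these compounds, whether a methyl or methoxy group on the same carbon would read the same stays open, as does chloro on the other carbons of this ring.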